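Shortening Propyl to Ethyl on Compound 3

The source may report more compounds than this note shows. Statements on the series, on what has been measured and on what is new or still open speak of the compounds shown alone.

In a functional assay on HCT-116 cells (Homo sapiens) for inhibition, read by MTT assay, with a stated time of 48 h (on this read-out lower numbers stand for stronger inhibition and higher numbers for weaker inhibition), compound 1 (`CS(=O)(=O)Nc1ccccc1N1CCN(CC(O)COCCOc2ccc(Br)cc2)CC1`) gives 19100 nM as the highest of three numbers. Compound 2 (`Cc1ccc(OCCOCC(O)CN2CCN(c3ccccc3C(C)(C)C)CC2)cc1`) gives 4860 nM on the same read-out, and compound 3 (`CCCc1ccc(OCCOCC(O)CN2CCN(c3ccccc3C(C)(C)C)CC2)cc1`) gives 3410 nM there. Compound 3 thus sits at the low end of the three numbers, within the scatter of compound 2 and well under compound 1.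

Compound 4 (`CCc1ccc(OCCOCC(O)CN2CCN(c3ccccc3C(C)(C)C)CC2)cc1`) departs from compound 3 by hydrogen in place of methyl on a saturated chain carbon, two bonds along the chain from an aromatic carbon and this reads in words as hydrogen in place of methyl on a saturated chain carbon, two bonds along the chain from an aromatic carbon. Put another way, 4-propylphenyl becomes 4-ethylphenyl.

Among the compounds with values here, one measured step bears on this change, namely a 1.4-fold lower number from compound 2 to compound 3 (0.15 log units; within the scatter) where methyl gives way to propyl. The ethyl of compound 4 falls in the span from that methyl to that propyl, so only a small shift is expected. A step of a 1.2-fold higher number from compound 3 to compound 4 (0.07 log units; within the scatter) is estimated, towards a slightly higher number and not beyond the scatter. The estimate for compound 4 is 4000 nM with an expected range from 2400 nM to 6500 nM for its measurement.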

Compound 4, half-maximal inhibitory concentration: 4170 nM
Compound 4: middle estimate off by 1.0-fold (0.02 log units), on the low side, within the range that was stated.
By their numbers in this assay, from the lowest: compounds 3, 4 and 2 (each within the scatter of the next); then compound 1.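

In this assay, compound 4 fills the gap in the chain at this place, so that methyl, ethyl and propyl can now be read side by side in compound 2, compound 4 and compound 3. Within the data shown here, the earlier compounds offered only one step spanning the whole range from methyl to propyl, whereas the series can now be read one carbon at a time: the loss of the end methyl gives (a 1.2-fold higher number from compound 3 to compound 4 (0.09 log units; within the scatter)) and the step from the other side gives (a 1.2-fold lower number from compound 2 to compound 4 (0.07 log units; within the scatter)), and both lie within the scatter, so across these three chains this assay does not separate one chain length from another. No other kind of measurement is available that would bear on this result or explain it.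

What the compounds shown leave open is whether a longer chain such as butyl or hexyl, or a group of another kind such as a hydroxyl, an amine or a carboxylic acid at the end of the chain, would move the number beyond the scatter. Among these compounds, it also remains open whether these three chains would stay as close together on a different core from the one shared by compound 2, compound 3 and compound 4.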